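The compounds below may be only part of what the source reports. "The series", "measured", "known", "first", "only" and "open" are said of these compounds alone.

Compound 1, `CCN1CCN(c2cccc3c2C[C@H](CN(C)[C@H]2CCCc4cccnc42)NC3)CC1`, gives 0% in an ADME assay on microsomes from liver (Homo sapiens) for metabolic stability, read by LC-MS, with a stated time of 10 min (a lower number here means that less of the compound is left, a higher number that more of the compound is left), the lowest of the three measured numbers; compound 3 is nearest and compound 2 furthest, both beyond the scatter. Compound 2, `CN(C[C@H]1Cc2c(cccc2N2CCN(c3cccc(C(F)(F)F)c3)CC2)CN1)[C@H]1CCCc2cccnc21`, gives 90.3% in this assay, and compound 3, `CN(C[C@H]1Cc2c(cccc2N2CCN(c3ncccn3)CC2)CN1)[C@H]1CCCc2cccnc21`, gives 35.5%. The measured steps at the same position are a number 90.3 percentage points higher from compound 1 to compound 2 (beyond the scatter), a number 35.5 percentage points higher from compound 1 to compound 3 (beyond the scatter) and a number 54.8 percentage points lower from compound 2 to compound 3 (beyond the scatter).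

Compound 4, `CN(C[C@H]1Cc2c(cccc2N2C[C@H]3C[C@@H]2CN3)CN1)[C@H]1CCCc2cccnc21`, differs from compound 1 at that position: a group of 7 heavy atoms (5 carbon, 2 nitrogen; 2 five-membered non-aromatic rings with 1 hetero atom each) in place of a group of 8 heavy atoms (6 carbon, 2 nitrogen; one six-membered non-aromatic ring with 2 hetero atoms), on an aromatic carbon. The three measured steps all exchange only the ethyl on the amine nitrogen in the ring and each moves the number by a large amount, so this position is sensitive. Within the data shown here, the change to compound 4 is different in kind, since the six-membered ring itself leaves and two five-membered rings with one hydrogen-bond donor enter, and no measured step matches it. Compound 4 is therefore expected to rise from compound 1 by a modest, uncertain amount, a number 20 percentage points higher from compound 1 to compound 4 (beyond the scatter). Compound 4 is estimated at 20%, within 0% to 50%.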

Compound 4, percent of the compound remaining: 100%
Compound 4: middle estimate off by 80 percentage points, on the low side; measured number outside the range, above it.
By their numbers in this assay, from the lowest: compound 1; then compound 3; then compounds 2 and 4 (each within the scatter of the next).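

Among these compounds, exchanging the whole 4-ethylpiperazin-1-yl group on the aromatic carbon, rather than only the ethyl on its ring nitrogen, gives a number 100 percentage points higher from compound 1 to compound 4 (beyond the scatter) in this assay and is the largest step so far. A high number at this position therefore does not require an aromatic ring on the amine nitrogen, since the entering group carries none and has 1 hydrogen-bond donor instead of 0. No measurement at hand bears on the reason for this step.

The compounds shown do not separate the loss of the ethyl from the change of ring, or either of these from the presence of the donor. On these data alone, a piperazin-1-yl group with hydrogen in place of the ethyl, and the entering group with an ethyl on its free amine nitrogen, remain open.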